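A few compounds are considered here, and "the series" means these few. Any claim that something is new, unique, unknown or untested is made for them only; others in the source may bear on it.

Measured compounds: compound 1 `NNC(=O)CSc1nnc(-c2ccncc2)o1`, compound 2 `O=C(CSc1nnc(-c2ccncc2)o1)N/N=C/c1cccc(F)c1`, compound 3 `O=C(CSc1nnc(-c2ccncc2)o1)N/N=C/c1cccc(C(F)(F)F)c1`. In a functional assay on BGC-823 cells (Homo sapiens) for cytotoxicity, read by MTT assay, with a stated time of 48 h (a higher number here means a weaker inhibitor, a lower number a stronger inhibitor), compound 1 gives 3260 nM, compound 2 gives 27500 nM, and compound 3 gives 13000 nM.

Among these three numbers compound 2 stands highest, that is, it is the weakest inhibitor of the set in this assay. Its nearest neighbour is compound 3, reached by a 2.1-fold lower number from compound 2 to compound 3 (0.33 log units; beyond the scatter), a change in which a trifluoromethyl replaces a fluoro on an aromatic carbon. Compound 1, which carries no arylidene group at all, lies furthest from compound 2.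

Compound 4 `O=C(CSc1nnc(-c2ccncc2)o1)N/N=C/c1ccc(O)c(O)c1` has not yet been measured. It differs from compound 2 in one place: 3,4-dihydroxyphenyl in place of 3-fluorophenyl on a carbon with a double bond to nitrogen. Within the data shown here, no measured step exchanges a halogen for hydroxyl groups on this ring, so the only step available for comparison is the modest one from compound 2 to compound 3, which changed the substituent on the same ring. The account therefore treats compound 2 as the starting point and expects, at most, a modest move in this assay, with direction uncertain. For compound 4 the estimated value is 15000 nM, with a range from 5000 nM to 45000 nM; the expected step is a 1.8-fold lower number from compound 2 to compound 4 (0.26 log units; within the scatter).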

Compound 4, half-maximal inhibitory concentration: 1260 nM
Estimate against measurement, compound 4: 12-fold (1.08 log units) above, and the stated range ends above it.
By their numbers in this assay, from the lowest: compound 4; then compound 1; then compound 3; then compound 2.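

In this assay, among these compounds, the aryl group on the carbon with a double bond to nitrogen proves far more consequential than the earlier compounds suggested: the move to 3,4-dihydroxyphenyl gives a 22-fold lower number from compound 2 to compound 4 (1.34 log units; beyond the scatter) and is classed as large. Among the compounds shown here, the only earlier change on this ring, a 2.1-fold lower number from compound 2 to compound 3 (0.33 log units; beyond the scatter) and classed as modest, exchanged one fluorinated substituent for another and gave no sign of a shift this size. The entering group carries hydrogen-bond donors and acceptors where the 3-fluorophenyl carries none, but no measurement here connects that difference to the result or explains it.

The compounds shown leave open whether both hydroxyl groups are needed or a single hydroxyl would give a similar number. They also leave open how methoxy groups or an amine on this ring would compare.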